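The source may hold more compounds than are shown below. What is called first, only, known or untested is meant among the compounds shown, and "the series" means these compounds.

Three compounds in this series carry a measured number in a functional assay on NCI-H322M cells (Homo sapiens) for cytotoxicity, read by sulforhodamine B assay, with a stated time of 48 h; on this read-out lower numbers stand for higher toxicity in this test and higher numbers for lower toxicity in this test. Compound 1, `ClCc1cccc(Cn2cnc3c(Cl)nc(Cl)nc32)c1`, gives 15900 nM in this assay. Compound 2, `ClCc1ccccc1Cn1cnc2ncnc(Cl)c21`, gives 40700 nM, and compound 3, `ClCc1ccccc1Cn1cnc2c(Cl)nc(Cl)nc21`, gives 5880 nM. Among these three numbers compound 1 stands second highest: its nearest neighbour is compound 2, whose higher number lies beyond the usual scatter, and the furthest is compound 3, whose lower number also lies beyond the scatter. No two of the measured compounds differ in only one place, so no single-change step can be read from them.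

Compound 4, `Nc1nc(Cl)c2ncn(Cc3cccc(CCl)c3)c2n1`, remains to be measured in this assay. Relative to compound 1 it differs by amino in place of chloro on an aromatic carbon, an amino in place of chloro on an aromatic carbon. Within the data shown here, with no comparable step available, the direction of the change rests on expectation alone: a modest rise in the number, toward lower toxicity in this test, seems plausible, but a result within the scatter cannot be excluded. For compound 4 the estimated value is 25000 nM, with a range from 8000 nM to 80000 nM, which corresponds to an expected step of a 1.6-fold higher number from compound 1 to compound 4 (0.20 log units; within the scatter).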

Compound 4, concentration lethal to 50% of the cells: 46800 nM
Compound 4: middle estimate off by 1.9-fold (0.27 log units), on the low side; the range from low to high includes it.
By their numbers in this assay, from the lowest: compound 3; then compound 1; then compounds 2 and 4 (each within the scatter of the next).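

Amino in place of chloro, on the aromatic carbon between two ring nitrogen atoms, gives the first single-change step in this series: in this assay the exchange produces a 2.9-fold higher number from compound 1 to compound 4 (0.47 log units; beyond the scatter), a shift toward lower toxicity in this test. The earlier compounds shown here could only suggest that this carbon matters, whereas this pair shows that changing the group there alone moves the number beyond the scatter. No available measurement gives a reason for this rise.

This is one exchange on one core, so it does not show whether a hydroxyl, methoxy or methylamino group at this carbon would move the number in the same direction or by a similar amount. Nor does it show whether amino in place of chloro would give a similar step on the core of compound 3.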